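Removing a Methoxy Group: What Compound 4 Might Show

This account rests on a few compounds, and the source may have more. Where it says the series, first, only, none or still open, it means among the compounds named here.

Compound 1 `COc1ccc(-c2cc(/C=C/C(=O)c3ccc(C)c(C)c3)nc3cc(-c4ccccc4)nn23)cc1OC`, compound 2 `COc1ccc(C(=O)/C=C/c2cc(-c3ccc(OC)cc3)n3nc(-c4ccccc4)cc3n2)cc1` and compound 3 `COc1cc(-c2cc(/C=C/C(=O)c3ccc(C)c(C)c3)nc3cc(-c4ccccc4)nn23)cc(OC)c1OC` were tested in a functional assay on A549 cells (Homo sapiens) for antiproliferative activity, read by MTT assay, with a stated time of 24 h; a lower number here means a stronger inhibitor, a higher number a weaker inhibitor. In this assay compound 1 gives 9300 nM, compound 2 gives 2900 nM and compound 3 gives 10600 nM; compound 2 stands lowest, beyond the scatter from both others. The change from compound 3 to compound 1 is hydrogen in place of methoxy on an aromatic carbon, and it made a 1.1-fold lower number from compound 3 to compound 1 (0.06 log units; within the scatter). The difference between the cores of compound 2 and compound 3 is not broken down here. Compound 4 `COc1ccc(-c2cc(/C=C/C(=O)c3ccccc3)nc3cc(-c4ccccc4)nn23)cc1` is not yet measured; it differs from compound 2 by hydrogen in place of methoxy on an aromatic carbon. This is the same kind of change as that from compound 3 to compound 1, but the place differs: in compound 4 it is para to a large group, whereas in compound 1 it was ortho to a methoxy group, meta to a large group and meta to a methoxy group. Because the earlier step of a 1.1-fold lower number from compound 3 to compound 1 (0.06 log units; within the scatter) stayed within the scatter, a small step is expected from compound 2 to compound 4 in this assay, namely a 1.2-fold higher number from compound 2 to compound 4 (0.08 log units; within the scatter). Compound 4 is therefore estimated at 3500 nM in this assay, with a range from 1500 nM to 8000 nM.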

Compound 4, half-maximal inhibitory concentration: 8600 nM
The estimate for compound 4 lay 2.5-fold (0.39 log units) below the measured number; measured number outside the range, above it.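

In this assay, hydrogen in place of methoxy, which turns a (4-methoxyphenyl)carbonyl group into benzoyl, made a 3.0-fold higher number from compound 2 to compound 4 (0.47 log units; beyond the scatter). Set beside the earlier step, the same change clearly did not carry over at one size from one core to the other: the same change on two cores in this assay, a 1.1-fold lower number (0.06 log units; within the scatter) from compound 3 to compound 1 and a 3.0-fold higher number (0.47 log units; beyond the scatter) from compound 2 to compound 4, 3.4-fold (0.53 log units) apart, beyond the scatter of two such steps. This does not show what sets the size of the step, since the two pairs differ in the place of the change as well as in the core, and two steps cannot separate these or establish a rule for the series.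

The compounds shown leave open what another group would do in place of this methoxy, for example a hydroxy group, a fluorine atom or an amine. They also leave open whether taking the methoxy from the remaining 4-methoxyphenyl group of compound 4 would give a step of similar size.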